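From 2-fluorobenzyl to 4-chlorobenzyl on a shared core

The compounds below may be only part of what the source reports. "The series", "measured", "known", "first", "only" and "open" are said of these compounds alone.

Of the compounds shown here, three sharing one core have been measured in a functional assay on HeLa cells (Homo sapiens) for antiproliferative activity, with a stated time of 24 h; on this read-out lower numbers stand for stronger inhibition and higher numbers for weaker inhibition. Compound 1 (`NC(=O)c1c(NC(=O)c2ccccc2Cl)sc2c1CCN(Cc1ccccc1)C2`) gives 38400 nM. Compound 2 (`N#Cc1ccccc1CN1CCc2c(sc(NC(=O)c3ccccc3Cl)c2C(N)=O)C1`) reaches only a limit of the assay, > 50000 nM. Compound 3 (`NC(=O)c1c(NC(=O)c2ccccc2Cl)sc2c1CCN(Cc1ccccc1F)C2`) likewise reaches only a limit, > 50000 nM. Compound 3 therefore has no number of its own and stands with compound 2 at the limit of > 50000 nM in this assay, at which 2 of the 3 values shown sit.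

The next compound, compound 4 (`NC(=O)c1c(NC(=O)c2ccccc2Cl)sc2c1CCN(Cc1ccc(Cl)cc1)C2`), differs from compound 3 by 4-chlorophenyl in place of 2-fluorophenyl on a saturated chain carbon bound to an amine nitrogen in a ring. In short, 4-chlorophenyl stands in place of 2-fluorophenyl on a saturated chain carbon bound to an amine nitrogen in a ring.

Among the compounds with values here, no measured step covers this exact change. The nearest evidence is an at least 1.3-fold higher number from compound 1 to compound 3 (0.11 log units; that floor lies within the scatter), together with an at least 1.3-fold higher number from compound 1 to compound 2 (0.11 log units; that floor lies within the scatter). Both floors lie within the scatter, and the remaining comparison is a step that the two limits leave unreadable from compound 2 to compound 3. These steps give no firm direction, so no change beyond the scatter is expected in this assay, and a further limit would be no surprise. The expected step is an at least 1.1-fold lower number from compound 3 to compound 4 (0.04 log units; that floor lies within the scatter). Compound 4 is estimated at 45000 nM, with an expected range from 20000 nM to 90000 nM.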

Compound 4, half-maximal inhibitory concentration: > 50000 nM
Compound 4 was reported as a limit; the forecaster's own chance of this, stated with the estimate: 55%; at least 1.1-fold (0.04 log units) between middle value and limit.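

Compound 4 shows that the limit is not confined to the two 2-substituted groups, 2-cyanobenzyl and 2-fluorobenzyl, since 4-chlorobenzyl on the same saturated chain carbon bound to an amine nitrogen in a ring also gives no number of its own in this assay: the limit of > 50000 nM in this assay, at which 3 of the 4 values shown sit.

Within the data shown here, the one readable step is an at least 1.3-fold higher number from compound 1 to compound 4 (0.11 log units; that floor lies within the scatter), so the change from benzyl to 4-chlorobenzyl gives no firm direction, as with the cyano and fluoro steps before it. The steps to compound 4 from compound 2 and from compound 3 cannot be read, since both ends of each are limits.

As far as these compounds go, whether compound 2, compound 3 and compound 4 truly differ from one another, or from compound 1, remains open. From the compounds shown here alone, it is also open whether an amine or a carboxylic acid on the phenyl ring, or a longer chain in place of the benzyl group, would give a readable number in this assay.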